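Working notes on a small antiproliferative series

The source may report more compounds than this note shows. Statements on the series, on what has been measured and on what is new or still open speak of the compounds shown alone.

Measured so far in a functional assay on L1210 cells (Mus musculus) for antiproliferative activity; on this read-out higher numbers stand for higher potency (the scale is a negative logarithm) and lower numbers for lower potency:
- compound 1 `CN(CCO)/N=N/c1ccccc1C(N)=O`: 3.07
- compound 2 `C=CCN(C)/N=N/c1ccccc1C(N)=O`: 3.43
- compound 3 `CN(C)/N=N/c1ccccc1C(N)=O`: 3.31

Compound 3 sits second of the three numbers, but both neighbours are within the scatter of it: the step of a number 0.12 log units lower from compound 2 to compound 3 (within the scatter) and the step of a number 0.24 log units higher from compound 1 to compound 3 (within the scatter) are each too small to call. For the measured compounds named here, the only step beyond the scatter is a number 0.36 log units higher from compound 1 to compound 2 (beyond the scatter), which replaces the hydroxymethyl by a vinyl at the same place.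

The next compound is compound 4 `CCCN(C)/N=N/c1ccccc1C(N)=O`, which differs from compound 3 by ethyl in place of hydrogen on a saturated chain carbon bound to an amine nitrogen. Going by the values given here, the steps that bear on this are those changing the group on a saturated chain carbon bound to an amine nitrogen; compound 1, compound 2 and compound 3 together show that hydrogen, vinyl and hydroxymethyl there all land within a narrow band, the largest spread being a number 0.36 log units higher from compound 1 to compound 2 (beyond the scatter). Methyl to propyl, a carbon chain without donors or acceptors, is expected to behave more like compound 2 than compound 1, so in this assay a step of about a number 0.14 log units higher from compound 3 to compound 4 (within the scatter) is expected, within the scatter. Compound 4 is therefore estimated at 3.45, between 3.1 and 3.8.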

Compound 4, logarithm of the reciprocal of the active concentration, log(1/C): 3.26
Compound 4: middle estimate off by 0.19 log units, on the high side; the range from low to high includes it.
By their numbers in this assay, from the lowest: compounds 1, 4, 3 and 2 (each within the scatter of the next, the first and the last beyond it).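

In this assay, ethyl in place of hydrogen on a saturated chain carbon bound to an amine nitrogen gives a number 0.05 log units lower from compound 3 to compound 4 (within the scatter) and ethyl in place of vinyl gives a number 0.17 log units lower from compound 2 to compound 4 (within the scatter) in the same place, so the saturated propyl chain falls in one band with the methyl of compound 3 and the unsaturated chain of compound 2. Methyl in place of hydroxy on a saturated chain carbon, two bonds along the chain from an amine nitrogen, gives a number 0.19 log units higher from compound 1 to compound 4 (within the scatter) and so does not repeat the separation beyond the scatter seen with compound 2 against compound 1. No supporting data bear on why these steps are small.

Going by these compounds, whether a longer chain such as octyl, a benzyl group, a terminal amine or a carboxylic acid at this place would leave the band remains open.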